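The source may hold more compounds than are shown below. What is called first, only, known or untested is meant among the compounds shown, and "the series" means these compounds.

Measured so far in a functional assay on MCF7 cells (Homo sapiens) for inhibition, read by sulforhodamine B assay, with a stated time of 48 h, tested at 10 uM; a lower number here means less inhibition, a higher number more inhibition at the concentration tested (going by the name of the read-out):
compound 1 `COc1ccc(-c2cn3ccnc3c(-c3ccc4ncn(C5CCCCC5)c4c3)n2)cc1`: 80.2%
compound 2 `Clc1ccc(-c2cn3ccnc3c(-c3ccc4ncn(C5CCCCC5)c4c3)n2)cc1`: 21.8%

Going by the values given here, compound 2 gives the lowest of the two numbers; its only neighbour is compound 1, which gives 80.2%. Among the compounds with values here, the single measured step is a number 58.4 percentage points lower from compound 1 to compound 2 (beyond the scatter), a large drop from one substitution on the pendant aryl ring.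

Compound 3 `FC(F)(F)c1cccc(-c2cn3ccnc3c(-c3ccc4ncn(C5CCCCC5)c4c3)n2)c1` is still to be measured in this assay. It carries 3-(trifluoromethyl)phenyl in place of 4-chlorophenyl on an aromatic carbon, that is 3-(trifluoromethyl)phenyl in place of 4-chlorophenyl on an aromatic carbon. Within the data shown here, no measured step covers this exchange; the methoxy-to-chloro step is the only guide, and it shows that a change at this place can move the number a great deal, without telling the direction for a trifluoromethyl group.

For compound 3 the expected step is therefore a number 8.2 percentage points higher from compound 2 to compound 3 (within the scatter), with no firm direction. The estimate for compound 3 is 30%, with a range from 5% to 70%.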

Compound 3, a percentage reported as inhibition, at one concentration (the size of the read-out at that concentration, not a potency): 19.9%
The estimate for compound 3 lay 10.1 percentage points above the measured number; measured number inside the range.
By their numbers in this assay, from the lowest: compounds 3 and 2 (each within the scatter of the next); then compound 1.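

In this assay, the exchange gives a number 1.9 percentage points lower from compound 2 to compound 3 (within the scatter), so 3-(trifluoromethyl)phenyl and 4-chlorophenyl cannot be told apart here, although the substituent and its ring position both differ. The second replacement of 4-methoxyphenyl also ends far from compound 1, with a number 60.3 percentage points lower from compound 1 to compound 3 (beyond the scatter), so among these three compounds the high number belongs to the 4-methoxyphenyl compound alone. No supporting data bear on the reason for this.

Because compound 3 changes the substituent and its ring position together, the contribution of each remains unresolved. Going by these compounds, it also remains open whether the high number is specific to methoxy or extends to other groups on the pendant ring, such as a hydroxyl, an ethoxy group or an amine.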